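Phenyl in place of methyl on an amine nitrogen

The compounds below may be only part of what the source reports. "The series", "measured", "known", "first", "only" and "open" are said of these compounds alone.

In a functional assay on HeLa cells (Homo sapiens) for antiproliferative activity, read by sulforhodamine B assay, with a stated time of 48 h (a lower number here means a stronger inhibitor, a higher number a weaker inhibitor), compound 1 `COc1ccc(C[C@@H](O)/C=C/C=C/C(=O)NCc2ccc(Cl)cc2)cc1OC` gives 13400 nM and compound 2 `COc1ccc(C[C@@H](O)/C=C/C=C/C(=O)N2CCN(C)CC2)cc1OC` gives 16500 nM as its value. Among the compounds with values here, these two values lie within the scatter of each other, so compound 2 holds no separate place on the numbers so far. Compound 3 `COc1ccc(C[C@@H](O)/C=C/C=C/C(=O)N2CCN(c3ccccc3)CC2)cc1OC` differs from compound 2 by one change: phenyl in place of methyl on an amine nitrogen in a ring with phenyl in place of methyl on an amine nitrogen in a ring. Within the data shown here, only one measured step bears on this, and it is a 1.2-fold higher number from compound 1 to compound 2 (0.09 log units; within the scatter) with 4-methylpiperazin-1-yl in place of (4-chlorobenzyl)amino on a carbonyl carbon. That step stayed within the scatter, but it did not test this nitrogen, so it offers only weak guidance. The expected step is a 1.3-fold lower number from compound 2 to compound 3 (0.10 log units; within the scatter) in this assay and no shift beyond the scatter is anticipated. For compound 3 the estimate is 13000 nM with an expected range from 5000 nM to 30000 nM in this measurement.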

Compound 3, half-maximal inhibitory concentration: 9750 nM
Compound 3: middle estimate off by 1.3-fold (0.12 log units), on the high side, and the stated range covers the measured number.
By their numbers in this assay, from the lowest: compounds 3, 1 and 2 (each within the scatter of the next).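

In this assay, within the data shown here, the amine nitrogen in the ring is varied directly here for the first time, since the earlier step replaced the whole amide substituent and left this position untested. Phenyl in place of methyl gives a 1.7-fold lower number from compound 2 to compound 3 (0.23 log units; within the scatter) at this nitrogen. This position therefore accepts an aromatic ring of carbon only in place of a single methyl carbon, with no shift beyond the scatter in this measurement. Nothing given here accounts for this step or its size.

Going by these compounds, it remains open whether a benzyl group, an acetyl group or a 4-chlorophenyl group on this nitrogen would move the number beyond the scatter. On these data alone, it also remains open whether a chain ending in a carboxylic acid or a primary amine would do so at this position.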